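A few compounds are considered here, and "the series" means these few. Any claim that something is new, unique, unknown or untested is made for them only; others in the source may bear on it.

Compound 1, `c1ccc(COc2ccc(OCCOCCNc3ccccc3)cc2)cc1`, carries an anilino end on its side chain. In a functional assay on SK-OV-3 cells (Homo sapiens) for inhibition, read by CCK-8 assay, with a stated time of 70 h (a higher number here means a weaker inhibitor, a lower number a stronger inhibitor), compound 1 gives > 100000 nM, which is a limit of the assay and not a measured number. Going by these compounds, compound 1 thus stands at the limit of > 100000 nM in this assay, at which 1 of the 3 values shown sits, and where it would sit beyond that point is unknown. Two further compounds from the same series were measured. Compound 2, `O=[N+]([O-])c1ccc(COc2ccc(OCCOCCNC3CCCC3)cc2)cc1`, gives 20300 nM in this assay. Compound 3, `c1cc2c(cc1OCCOCCNC1CCCC1)CCCC2`, gives 31900 nM in this assay. Within the data shown here, both carry a cyclopentylamino end and both return numbers rather than limits, but no single-point step connects either of them to compound 1.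

Compound 4, `c1ccc(COc2ccc(OCCOCCNC3CC3)cc2)cc1`, has not yet been measured. It differs from compound 1 in one place: cyclopropyl in place of phenyl on an amine nitrogen. Among the measured compounds shown here, no measured step covers this exchange, so the expected size of the change can only be set from where compound 1 stands and from the numbers given by compounds 2 and 3. Compound 4 is expected to come in near 60000 nM, within a range from 20000 nM to 200000 nM. The step of an at least 1.6-fold lower number from compound 1 to compound 4 (0.22 log units; that floor lies within the scatter) is expected to run toward stronger inhibition, with a real chance that compound 4 also returns only a limit.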

Compound 4, half-maximal inhibitory concentration: 47200 nM
Compound 4: the middle estimate sits 1.3-fold (0.10 log units) above what was measured; the range from low to high includes it.
By their numbers in this assay, from the lowest: compounds 2, 3 and 4 (each within the scatter of the next, the first and the last beyond it). At a limit, above all of these: compound 1.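

Cyclopropyl in place of phenyl on the amine nitrogen gives an at least 2.1-fold lower number from compound 1 to compound 4 (0.32 log units; beyond the scatter) in this assay, the first step in this series that can be read at this position. Going by these compounds, compound 1 stands at a limit and not at a measured number, so this step gives only the smallest size the change can have, and its true size stays unknown: the limit of > 100000 nM in this assay, at which 1 of the 4 values shown sits. With the rest of the structure held the same, this single exchange of an anilino end for a cyclopropylamino end moves the read-out from a limit to a measured number, which shows that the group on this nitrogen matters here, although one step is no trend.

The compounds shown do not separate ring size from the loss of the aromatic ring, since the six-membered aromatic ring of carbon leaves and the three-membered non-aromatic ring of carbon enters in the same exchange. They also leave open where a cyclobutyl, an isopropyl or a benzyl group on the same amine nitrogen would fall, and whether a longer chain to that nitrogen would shift the number further.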